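Bromo for methoxy on the oxime aryl ring

The source may report more compounds than this note shows. Statements on the series, on what has been measured and on what is new or still open speak of the compounds shown alone.

Compound 1 `COc1ccc(C(/C=C/c2ccc(Cl)cc2)=N/O)cc1` is one of three oximes tested in a functional assay (Mus musculus, strain Balb/c) for inhibition, read by ELISA, with a stated time of 72 h (a lower number here means a stronger inhibitor, a higher number a weaker inhibitor), where compound 1 gives 11500 nM. Compound 2 `COc1ccc(C(/C=C/c2ccc(F)cc2)=N/O)cc1` gives 11000 nM and compound 3 `COc1ccc(C(/C=C/c2ccc(Cl)cc2Cl)=N/O)cc1` gives 11200 nM; compound 1 has the highest of the three numbers, but both neighbours lie within the scatter of it. Compound 4 `O/N=C(\C=C\c1ccc(Cl)cc1)c1ccc(Br)cc1` differs from compound 1 by bromo in place of methoxy on an aromatic carbon. Among the measured compounds shown here, the two measured steps, a 1.0-fold lower number from compound 1 to compound 2 (0.02 log units; within the scatter) and a 1.0-fold lower number from compound 1 to compound 3 (0.01 log units; within the scatter), change halogens on the other aromatic ring and were both flat, so no step on this ring has been measured. The change is therefore expected to be near a 1.0-fold lower number from compound 1 to compound 4 (0.02 log units; within the scatter), and compound 4 is estimated at 11000 nM, between 4000 nM and 30000 nM.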

Compound 4, half-maximal inhibitory concentration: 14700 nM
The estimate for compound 4 lay 1.3-fold (0.13 log units) below the measured number, within the range that was stated.
By their numbers in this assay, from the lowest: compounds 2, 3, 1 and 4 (each within the scatter of the next).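

In this assay the first change measured on this ring, bromo in place of methoxy para to a large group, gives a 1.3-fold higher number from compound 1 to compound 4 (0.11 log units; within the scatter) and so shows that the methoxy can be replaced here without a change beyond the scatter. The number therefore stays as flat for this replacement on this ring as it did for the halogen changes on the other ring. No evidence is available to explain this result. The compounds shown leave open whether an amine, a carboxylic acid or a longer alkoxy chain at this position would move the number beyond the scatter.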